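A few compounds are considered here, and "the series" means these few. Any claim that something is new, unique, unknown or untested is made for them only; others in the source may bear on it.

In a functional assay on SK-BR-3 cells (Homo sapiens) for antiproliferative activity (a lower number here means a stronger inhibitor, a higher number a weaker inhibitor), compound 2 `CC(C)=CCc1cc(C(=O)Nc2cc3ccc(OCCCN(C(C)C)C(C)C)c(C)c3oc2=O)ccc1O` gives 1600 nM and compound 1 `CC(C)=CCc1cc(C(=O)Nc2cc3ccc(OCC4CCN(C)C4)c(C)c3oc2=O)ccc1O` gives 920 nM there, so the two cannot be told apart. Compound 3 `CC(C)=CCc1cc(C(=O)Nc2cc3ccc(OCCCN(C)C(C)(C)C)c(C)c3oc2=O)ccc1O` differs from compound 2 by one swap methyl(tert-butyl)amino in place of diisopropylamino on a saturated chain carbon, three bonds along the chain from an oxygen on an aromatic ring and it can be put in words: methyl(tert-butyl)amino stands in place of diisopropylamino on a saturated chain carbon, three bonds along the chain from an oxygen on an aromatic ring. Among the measured compounds shown here, only one measured step bears on this, and it also alters the group carried on that oxygen. That step reads a 1.7-fold higher number from compound 1 to compound 2 (0.24 log units; within the scatter) and gives no sign of a real shift. One step is thin evidence, but no step beyond the scatter is expected in this assay for the new swap. The estimated change is a 1.1-fold lower number from compound 2 to compound 3 (0.06 log units; within the scatter) and so no real shift. The expected value for compound 3 is 1400 nM with 650 nM to 3000 nM as its likely range.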

Compound 3, half-maximal inhibitory concentration: 880 nM
For compound 3 the middle estimate is 1.6-fold (0.20 log units) above the measured one; low and high end bracket the measured number.
By their numbers in this assay, from the lowest: compounds 3, 1 and 2 (each within the scatter of the next).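

In this assay, the swap of diisopropylamino for methyl(tert-butyl)amino on a saturated chain carbon, three bonds along the chain from an oxygen on an aromatic ring, reads a 1.8-fold lower number from compound 2 to compound 3 (0.26 log units; within the scatter), so a second change to this side chain also gives no real shift. Replacing the 1-methylpyrrolidin-3-yl group with the open-chain 2-(methyl(tert-butyl)amino)ethyl group reads a 1.0-fold lower number from compound 1 to compound 3 (0.02 log units; within the scatter), so the ring and open-chain forms cannot be told apart among these compounds. The data offer no explanation for why these three side chains give such similar read-outs.

From the compounds shown here alone, it remains open whether this tolerance extends beyond these amines. A carboxylic acid or a hydroxyl group at the chain end, or a longer chain, could still give a clearly different number.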